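Pyrrolidin-1-yl for 4-methylpiperazin-1-yl on a carbonyl carbon

The source may hold more compounds than are shown below. What is called first, only, known or untested is meant among the compounds shown, and "the series" means these compounds.

In a functional assay on HCT-116 cells (Homo sapiens) for cytotoxicity (a lower number here means a stronger inhibitor, a higher number a weaker inhibitor), compound 1 `COc1cc(N2CCNCC2)ccc1Nc1nc(NC2CCCCC2)c2nc[nH]c2n1` gives 88 nM and compound 2 `COc1cc(N2CCC(CC(=O)N3CCN(C)CC3)CC2)ccc1Nc1nc(NC2CCCCC2)c2nc[nH]c2n1` gives 51 nM with the two values within the scatter of each other. Compound 3 `COc1cc(N2CCC(CC(=O)N3CCCC3)CC2)ccc1Nc1nc(NC2CCCCC2)c2nc[nH]c2n1` differs from compound 2 by pyrrolidin-1-yl in place of 4-methylpiperazin-1-yl on a carbonyl carbon with pyrrolidin-1-yl in place of 4-methylpiperazin-1-yl on a carbonyl carbon. Within the data shown here, no measured step covers this change, so the only guide is the closeness of compound 1 at 88 nM and compound 2 at 51 nM in this assay despite their different structures. The expected 1.2-fold higher number from compound 2 to compound 3 (0.07 log units; within the scatter) stays within the scatter. For compound 3 the estimated value is 60 nM (expected range 20 nM to 180 nM).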

Compound 3, half-maximal inhibitory concentration: 15 nM
The estimate for compound 3 lay 4.0-fold (0.60 log units) above the measured number; the measured number lies below the stated range.
By their numbers in this assay, from the lowest: compound 3; then compounds 2 and 1 (each within the scatter of the next).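

In this assay, the group on this carbonyl carbon matters: pyrrolidin-1-yl in place of 4-methylpiperazin-1-yl gives a 3.4-fold lower number from compound 2 to compound 3 (0.53 log units; beyond the scatter), a step beyond the scatter. Among these compounds, this is the first single-place comparison, and it shows that the read-out responds to the ring at the end of this side chain. Nothing at hand explains the step.

Still open, on these data alone, is whether the step follows from the ring size or from the loss of the second ring nitrogen. A piperidin-1-yl or morpholin-4-yl group on the same carbonyl carbon would separate the two.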